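The source may report more compounds than this note shows. Statements on the series, on what has been measured and on what is new or still open speak of the compounds shown alone.

Of the compounds shown here, two of a shared core have been measured in a toxicity assay on HepG2 cells (Homo sapiens) for inhibition, read by CellTiter-Glo, with a stated time of 48 h; on this read-out higher numbers stand for weaker inhibition and lower numbers for stronger inhibition. Compound 1 `COc1ccc2nc(C)cc(NCC(=O)Nc3cc(C)cc(C)c3)c2c1` gives 6310 nM in this assay. Going by the values given here, compound 2 `COc1ccc2nc(C)cc(OCC(=O)Nc3ccc(Br)c(C)c3)c2c1` gives 15900 nM in this assay, the highest of the two numbers; the only neighbour, compound 1, sits lower by a margin beyond the usual scatter, so compound 2 is the weaker inhibitor of the pair.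

Compound 3 `COc1ccc2nc(C)cc(OCC(=O)Nc3nccs3)c2c1` differs from compound 2 in one place: 1,3-thiazol-2-yl in place of 4-bromo-3-methylphenyl on an amide-type nitrogen. Among the compounds with values here, no measured pair here shows this kind of change, so the size of the step in this assay cannot be read off from the data; the expectation is for a modest move towards a higher number, from compound 2 to compound 3, though a step within the scatter would not surprise. Compound 3 is therefore expected to give about 22000 nM, estimated between 8000 nM and 60000 nM, which corresponds to an expected step of a 1.4-fold higher number from compound 2 to compound 3 (0.14 log units; within the scatter).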

Compound 3, half-maximal inhibitory concentration: > 100000 nM
Compound 3: only a limit was reported; the forecaster's own chance of this, stated with the estimate: 25%; middle value at least 4.5-fold (0.65 log units) from the limit.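

In this assay, 1,3-thiazol-2-yl in place of 4-bromo-3-methylphenyl on the amide-type nitrogen gives an at least 6.2-fold higher number from compound 2 to compound 3 (0.79 log units; beyond the scatter), towards weaker inhibition. Going by these compounds alone, compound 1 and compound 2 differ in more than one place, so this pair is the first to show that a change at this one position alone can move the read-out beyond the scatter. For compound 3, only a limit was reported, not a number: the limit of > 100000 nM in this assay, at which 1 of the 3 values shown sits.

The bromine, the methyl and the six-membered carbon ring all leave together, so the compounds shown do not separate their shares in this step. They also leave open how an unsubstituted phenyl or a pyridin-2-yl group would read on this nitrogen, and whether 1,3-thiazol-2-yl would act alike on the core of compound 1.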